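The source may hold more compounds than are shown below. What is called first, only, known or untested is meant among the compounds shown, and "the series" means these compounds.

Of the compounds shown here, three have been tested in a toxicity assay on NIH3T3 cells (Mus musculus) for cytotoxicity, read by resazurin assay (on this read-out higher numbers stand for an effect only at larger amounts of compound and lower numbers for an effect already at smaller amounts), and none of them has given a number. Compound 1 `N#Cc1ccc(NCc2cncn2Cc2ccc(-c3ccccc3)cc2N)cc1-c1ccccc1` reads > 1000 nM, which is a limit. Compound 2 `Cc1cccc(-c2cccc(NCc3cncn3Cc3ccccc3)c2)c1` reads > 1000 nM, also a limit. Compound 3 `c1ccc(-c2ccc(Cn3cncc3CNc3ccc(-c4cc5ccccc5o4)c(-c4ccccc4)c3)cc2)cc1` reads > 10000 nM, again a limit. For the measured compounds named here, compound 2 therefore stands on (the limit of > 1000 nM in this assay, at which 2 of the 3 values shown sit), and the one remaining reading is the limit of > 10000 nM in this assay, at which 1 of the 3 values shown sits.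

Compound 4 `CC(C)c1cccc(NCc2cncn2Cc2ccccc2)c1` carries isopropyl in place of 3-methylphenyl on an aromatic carbon, meta to a large group: isopropyl in place of 3-methylphenyl on an aromatic carbon. Going by the values given here, no two measured compounds differ in one place, so no measured step gives a size for this change. The expected change in this assay is small, a step that the limit leaves unreadable from compound 2 to compound 4, towards a higher number or else none beyond the scatter. That expectation rests on compound 2, whose reading of > 1000 nM is a limit. For compound 4 the estimated half-maximal effective concentration is 3000 nM, with an expected range of 1000 nM to 20000 nM.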

Compound 4, half-maximal effective concentration: > 1000 nM
Compound 4: a limit, no number; the forecaster's own chance of this, stated with the estimate: 85%; the middle value lies beyond the limit too.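

For the compounds shown here, compound 2 and compound 4 both read as limits in this assay, so no step between them can be read. The compounds shown leave open where any of the four would give a number, and whether isopropyl in place of 3-methylphenyl changes the reading.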